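Lactone amides with phenyl-capped chains: lengthening the chain

The compounds below may be only part of what the source reports. "The series", "measured", "known", "first", "only" and "open" are said of these compounds alone.

Measured so far, in a functional assay on NCI-H630 cells (Homo sapiens) for cytotoxicity, read by sulforhodamine B assay, with a stated time of 5 days; a lower number here means a stronger inhibitor, a higher number a weaker inhibitor:
compound 1 `O=C(CCCCCCCCc1ccccc1)N[C@H]1CCOC1=O` gives > 100000 nM
compound 2 `O=C(CCCCCCc1ccccc1)CC(=O)N[C@H]1CCOC1=O` gives 65000 nM
compound 3 `O=C(CCc1ccccc1)CC(=O)N[C@H]1CCOC1=O` gives > 100000 nM

Within the data shown here, compound 2 is the only member of the series with a numerical reading in this assay; the other two entries are limits of the assay rather than numbers. For compound 1 the reading is a limit, > 100000 nM. For compound 3 the reading is likewise a limit, > 100000 nM. Among the measured compounds shown here, both sit at the limit of > 100000 nM in this assay, at which 2 of the 3 values shown sit, so compound 2 stands alone as the one compound that can be placed on the scale at all, and its reading is itself weak.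

Compound 4 `O=C(CCCCCCCCCc1ccccc1)CC(=O)N[C@H]1CCOC1=O` is the next compound to be measured in this assay. It differs from compound 2 in one place: 3-phenylpropyl in place of phenyl on a saturated chain carbon, six bonds along the chain from a carbonyl carbon. Among the measured compounds, the shorter-chained compound 3 returns a limit while compound 2 returns a number, and compound 4 extends the chain further in the same sense. For the measured compounds named here, no measured step is available to calibrate such a change, so the expectation is a modest one.

Compound 4 is expected to be somewhat stronger than compound 2, a step of a 2.2-fold lower number from compound 2 to compound 4 (0.34 log units; beyond the scatter), though a result within the scatter or a limit cannot be excluded. The estimate for compound 4 in this assay is 30000 nM, within 8000 nM to 100000 nM.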

Compound 4, half-maximal inhibitory concentration: 16000 nM
Compound 4: middle estimate off by 1.9-fold (0.27 log units), on the high side; the range from low to high includes it.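

In this assay, among these compounds, 3-phenylpropyl in place of phenyl on a saturated chain carbon, six bonds along the chain from a carbonyl carbon, gives a 4.1-fold lower number from compound 2 to compound 4 (0.61 log units; beyond the scatter); this is the only measured step, and it lies beyond the scatter. The gain is real but does not make a strong compound, since compound 4 still gives only 16000 nM, so the result shows a direction at this position and no more than that. The earlier compounds gave one number and no readable change at this position, whereas this change places a second compound on the scale and does not send it to the limit that holds most of the other readings: the limit of > 100000 nM in this assay, at which 2 of the 4 values shown sit.

On these data alone, a single step sets no trend, so it remains open whether a longer chain than 3-phenylpropyl would continue the gain, level off or return to the limit. As far as these compounds go, it also remains open whether the phenyl itself matters, a question that an amine or a carboxylic acid in its place would address.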